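Methyl for methoxy on the shared core: working notes

The source may hold more compounds than are shown below. What is called first, only, known or untested is meant among the compounds shown, and "the series" means these compounds.

Measured so far:
compound 1 `COc1ccc2nc(NC(=O)c3cn(-c4ccccc4)nc3-c3ccc(Cl)cc3)sc2c1` — in a functional assay on A549 cells (Homo sapiens) for cytotoxicity, read by MTT assay, with a stated time of 72 h (a higher number here means a weaker inhibitor, a lower number a stronger inhibitor), compound 1 gives 31400 nM
compound 2 `Cc1ccc2nc(NC(=O)c3cn(-c4ccccc4)nc3-c3ccc(Cl)cc3)sc2c1` — in this assay compound 2 gives 18600 nM
compound 3 `COc1ccc(-c2nn(-c3ccccc3)cc2C(=O)Nc2nc3ccc(OC)cc3s2)cc1` — in this assay compound 3 gives 18900 nM

Compound 2 differs from compound 1 by methyl in place of methoxy on an aromatic carbon and the step is a 1.7-fold lower number from compound 1 to compound 2 (0.23 log units; within the scatter). Compound 3 differs from compound 1 by methoxy in place of chloro on an aromatic carbon, with the step of a 1.7-fold lower number from compound 1 to compound 3 (0.22 log units; within the scatter). All three numbers sit close together and none of the steps leaves the scatter.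

Compound 4 `COc1ccc(-c2nn(-c3ccccc3)cc2C(=O)Nc2nc3ccc(C)cc3s2)cc1` has not been measured. It differs from compound 3 by methyl in place of methoxy on an aromatic carbon. This is the same change as from compound 1 to compound 2, at a place described in the same words, so it is the same change made on the other core; the two cores differ by methoxy in place of chloro on an aromatic carbon.

For compound 4 the expected step in this assay is a 1.5-fold lower number from compound 3 to compound 4 (0.16 log units; within the scatter), resting on the measured 1.7-fold lower number from compound 1 to compound 2 (0.23 log units; within the scatter), which stayed within the scatter. Compound 4 is therefore estimated at 13000 nM, expected to lie between 6000 nM and 30000 nM.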

Compound 4, half-maximal inhibitory concentration: 27700 nM
Beside the measured number, compound 4's estimate is 2.1-fold (0.33 log units) below it; the measured number falls inside the stated range.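

In this assay the change of methyl in place of methoxy on the core of compound 3 reads as a 1.5-fold higher number from compound 3 to compound 4 (0.17 log units; within the scatter) and cannot be told apart from the same change on the core of compound 1: the same change on two cores in this assay, a 1.7-fold lower number (0.23 log units; within the scatter) from compound 1 to compound 2 and a 1.5-fold higher number (0.17 log units; within the scatter) from compound 3 to compound 4, 2.5-fold (0.39 log units) apart, within the scatter of two such steps.
The change of methoxy in place of chloro reads as a 1.5-fold higher number from compound 2 to compound 4 (0.17 log units; within the scatter) and likewise cannot be told apart from its earlier step: the same change on two cores in this assay, a 1.7-fold lower number (0.22 log units; within the scatter) from compound 1 to compound 3 and a 1.5-fold higher number (0.17 log units; within the scatter) from compound 2 to compound 4, 2.5-fold (0.39 log units) apart, within the scatter of two such steps.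
Both changes therefore carry between these cores without any step leaving the scatter, but all four steps lie within it, so the data show neither a real effect of either change nor a fixed direction, and this single set of four compounds does not establish transfer across the wider series.

Open, from the compounds shown here alone, is whether in this assay an amine or a carboxylic acid at the place held by methoxy and methyl would give a step beyond the scatter. Also open, going by these compounds, is whether a longer chain in the place held by chloro and methoxy would do so, which would give a larger step to compare between cores.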